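Bile acid receptor agonists: varying the acid-bearing tail

The compounds below may be only part of what the source reports. "The series", "measured", "known", "first", "only" and "open" are said of these compounds alone.

Measured compounds:
compound 1 `CC(C)c1onc(-c2c(Cl)cccc2Cl)c1COc1ccc(NC(=O)c2ccc(C(=O)O)cc2)c(C(F)(F)F)n1` — 48%
compound 2 `CC(C)c1onc(-c2c(Cl)cccc2Cl)c1COc1ccc(N(C)Cc2ccc(CCC(=O)O)cc2)c(C(F)(F)F)n1` — 66%

Two compounds of this series have been run in a functional assay on HEK293 cells for agonist activity at Bile acid receptor (Homo sapiens), read by a luciferase reporter; on this read-out lower numbers stand for smaller maximal responses and higher numbers for larger maximal responses. Compound 1 reaches 48% in this assay, while compound 2 gives 66%, the higher of the two numbers; the gap between them lies beyond the usual scatter of repeated measurements. Going by the values given here, the two compounds differ in more than one place, so no single-point step can be drawn from them, and their two values are all that can be said.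

Compound 3 `CC(C)c1onc(-c2c(Cl)cccc2Cl)c1COc1ccc(N(C)Cc2ccc(OCC(=O)O)cc2)c(C(F)(F)F)n1` is the next compound to be measured in this assay. Relative to compound 2 it carries carboxymethoxy in place of 2-carboxyethyl on an aromatic carbon. The acid-bearing group keeps its size and stays at the same place on the benzyl ring, so a small step is expected, with no clear direction beyond the scatter. The expected step for this change is a number 4 percentage points lower from compound 2 to compound 3 (within the scatter). Compound 3 is therefore estimated to reach 62% in this assay, with a range from 42% to 82%.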

Compound 3, largest response reached (reported as efficacy), in percent of the reference or control that the assay uses: 59%
Estimate against measurement, compound 3: 3 percentage points above; the range from low to high includes it.
By their numbers in this assay, from the lowest: compound 1; then compounds 3 and 2 (each within the scatter of the next).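

Carboxymethoxy in place of 2-carboxyethyl on the aromatic carbon para to a large group gives the first single-place reading in this series: the step reads a number 7 percentage points lower from compound 2 to compound 3 (within the scatter) in this assay and is the only comparison of this kind so far. At this position, the exchanged groups have the same count of 5 heavy atoms but differ in make-up (3 carbon and 2 oxygen in 2-carboxyethyl, 2 carbon and 3 oxygen in carboxymethoxy), and this read-out does not separate the 4-(2-carboxyethyl)benzyl and 4-(carboxymethoxy)benzyl tails. Nothing at hand speaks to why these two tails read alike.

Left open is how a tetrazole in place of the carboxylic acid, or a longer chain such as 3-carboxypropyl on the same aromatic carbon, would read in this assay and whether either would separate from these tails. Compound 1 differs from compound 2 and from compound 3 in more than one place, so its steps to them cannot be read and the part played by its amide link remains unresolved.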